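Benzyl in Place of Isopropyl on the Ether Oxygen

This account rests on a few compounds, and the source may have more. Where it says the series, first, only, none or still open, it means among the compounds named here.

Of the compounds shown here, three sharing one core have been tested in an assay on membranes from HEK293 cells for displacement of a labelled ligand from Translocator protein (Homo sapiens), read by scintillation counting, with a stated time of 90 min; a higher number here means a weaker inhibitor, a lower number a stronger inhibitor. Compound 1 `COc1ccc(CN(C(C)=O)c2cc(C)cc(C)c2)cc1` gives 500 nM, compound 2 `CC(=O)N(Cc1ccc(OCCF)cc1)c1cc(C)cc(C)c1` gives 275 nM, and compound 3 `CC(=O)N(Cc1ccc(OC(C)C)cc1)c1cc(C)cc(C)c1` gives 823 nM. Compound 3 has the highest of these three numbers: the step of a 1.6-fold higher number from compound 1 to compound 3 (0.22 log units; within the scatter) stays within the scatter, while the step of a 3.0-fold higher number from compound 2 to compound 3 (0.48 log units; beyond the scatter) goes beyond it. Compound 4 `CC(=O)N(Cc1ccc(OCc2ccccc2)cc1)c1cc(C)cc(C)c1` carries benzyl in place of isopropyl on an oxygen on an aromatic ring. Both measured steps changed the group on this same oxygen and were small, and neither brought in a ring, so they give only weak guidance for a benzyl group. The step expected here is a 1.3-fold higher number from compound 3 to compound 4 (0.13 log units; within the scatter), towards a somewhat weaker inhibitor. Compound 4 is estimated at 1100 nM, with a range from 300 nM to 4000 nM.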

Compound 4, inhibition constant: 377 nM
For compound 4 the middle estimate is 2.9-fold (0.47 log units) above the measured one, and the stated range covers the measured number.
By their numbers in this assay, from the lowest: compounds 2, 4, 1 and 3 (each within the scatter of the next, the first and the last beyond it).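

On this oxygen an aromatic ring is tolerated: a 2.2-fold lower number from compound 3 to compound 4 (0.34 log units; beyond the scatter) goes beyond the scatter, so benzyl does not weaken the compound relative to isopropyl. Set against the methyl and 2-fluoroethyl ethers, a 1.3-fold lower number from compound 1 to compound 4 (0.12 log units; within the scatter) and a 1.4-fold higher number from compound 2 to compound 4 (0.14 log units; within the scatter) both stay within the scatter, so compound 4 cannot be ordered against compound 1 or compound 2. Nothing available explains the difference between benzyl and isopropyl. Still open, from the compounds shown here alone, is how a longer chain ending in a phenyl ring, an amine or a carboxylic acid would behave on this oxygen.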